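A few compounds are considered here, and "the series" means these few. Any claim that something is new, unique, unknown or untested is made for them only; others in the source may bear on it.

Measured in a functional assay on A549 cells (Homo sapiens) for antiproliferative activity, read by MTT assay, with a stated time of 48 h; on this read-out lower numbers stand for stronger inhibition and higher numbers for weaker inhibition:
Compound 1 `COc1ccc(/C=C/c2cc(OC)cc(OC)c2/C=C/C(=O)c2ccc(C)cc2)cc1`: 3.6 ug/mL
Compound 2 `COc1ccc(/C=C/c2cc(OC)cc(OC)c2/C=C/C(=O)c2cccc(Br)c2)cc1`: 8.1 ug/mL
Compound 3 `COc1ccc(/C=C/c2cc(OC)cc(OC)c2/C=C/C(=O)c2ccc(Cl)cc2)cc1`: 6.4 ug/mL

In this assay, compound 3 stands within the scatter of both other compounds, with a 1.3-fold lower number from compound 2 to compound 3 (0.10 log units; within the scatter) and a 1.8-fold higher number from compound 1 to compound 3 (0.25 log units; within the scatter). Compound 4 `COc1ccc(/C=C/c2cc(OC)cc(OC)c2/C=C/C(=O)c2ccc(C)c(C)c2)cc1` has 3,4-dimethylphenyl in place of 4-chlorophenyl on a carbonyl carbon.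

The closest evidence is the exchange of methyl and chloro on an aromatic carbon, which gave a 1.8-fold higher number from compound 1 to compound 3 (0.25 log units; within the scatter), a step within the scatter. The change to compound 4 runs the opposite way, restoring methyl in place of chloro, so a slightly lower number is the likely direction. Among the measured compounds shown here, the further methyl has no measured counterpart. The widest measured step, a 2.3-fold higher number from compound 1 to compound 2 (0.35 log units; beyond the scatter), is only modest, which argues against expecting a large change. The expected step is a 1.3-fold lower number from compound 3 to compound 4 (0.12 log units; within the scatter), not beyond the scatter. The estimated value for compound 4 is 4.8 ug/mL, with an expected range from 2.2 ug/mL to 10 ug/mL.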

Compound 4, half-maximal inhibitory concentration: 0.1 ug/mL
Compound 4: middle estimate off by 48-fold (1.68 log units), on the high side; measured number below the stated range.
By their numbers in this assay, from the lowest: compound 4; then compounds 1, 3 and 2 (each within the scatter of the next, the first and the last beyond it).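

In this assay, among the compounds shown here, the aryl group on the carbonyl carbon proved far more sensitive than the earlier compounds suggested: they gave only a modest step at most, whereas methyl in place of hydrogen on an aromatic carbon gave a 36-fold lower number from compound 1 to compound 4 (1.56 log units; beyond the scatter) and so turned a small change into a large one. The 3,4-dimethylphenyl group also gave a 64-fold lower number from compound 3 to compound 4 (1.81 log units; beyond the scatter) in place of 4-chlorophenyl and an 81-fold lower number from compound 2 to compound 4 (1.91 log units; beyond the scatter) in place of 3-bromophenyl, which makes compound 4 the most potent of the four. Nothing measured here explains why one added methyl carries so much weight.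

As far as these compounds go, whether the added methyl works only together with the methyl already present in compound 1 stays open. So does whether an ethyl group or an amine in its place would keep the gain.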